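Working notes: compound 1 to compound 3 in the cytotoxicity series

The compounds below may be only part of what the source reports. "The series", "measured", "known", "first", "only" and "open" are said of these compounds alone.

Going by the values given here, compound 1 `O=C1C(=Cc2ccc(O)cc2)C(=O)N(c2ccc(Cl)cc2)N1c1ccc(Cl)cc1` is the only member of this set with a numerical value in a functional assay on ECa-109 cells (Homo sapiens) for cytotoxicity, read by MTT assay, with a stated time of 72 h; a higher number here means a weaker inhibitor, a lower number a stronger inhibitor; compound 1 gives 34200 nM. Compound 2 `COc1ccc(C=C2C(=O)N(c3ccc(Cl)cc3)N(c3ccc(Cl)cc3)C2=O)cc1` carries methyl in place of hydrogen on an oxygen on an aromatic ring. In this assay compound 2 reaches only a limit of the assay, > 128000 nM. Among the compounds with values here, the step of an at least 3.7-fold higher number from compound 1 to compound 2 (0.57 log units; beyond the scatter) is the single measured step here, and it rests on the limit (the limit of > 128000 nM in this assay, at which 1 of the 2 values shown sits). Compound 3 `O=C1C(=Cc2ccc(Cl)cc2Cl)C(=O)N(c2ccc(Cl)cc2)N1c1ccc(Cl)cc1` differs from compound 1 by 2,4-dichlorophenyl in place of 4-hydroxyphenyl on a double-bonded chain carbon bound to a double-bonded ring carbon. Like the methyl change in compound 2, this change leaves no free hydroxyl on the ring attached to the double-bonded chain carbon, so a step toward a higher number, of about the measured size, is expected for compound 3 in this assay, namely a 3.2-fold higher number from compound 1 to compound 3 (0.51 log units; beyond the scatter). Compound 3 is estimated at 110000 nM, in the range 30000 nM to 250000 nM, with a fair chance that only a limit is returned.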

Compound 3, half-maximal inhibitory concentration: 60200 nM
Compound 3: the middle estimate sits 1.8-fold (0.26 log units) above what was measured; low and high end bracket the measured number.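

At the position on a double-bonded chain carbon bound to a double-bonded ring carbon, the loss of the free hydroxyl does not by itself produce a step beyond the scatter in this assay: 2,4-dichlorophenyl in place of 4-hydroxyphenyl gives a 1.8-fold higher number from compound 1 to compound 3 (0.25 log units; within the scatter). Compound 2, also without a free hydroxyl on this ring, therefore goes against any reading of the hydroxyl as the sole determinant, and 2,4-dichlorophenyl in place of 4-methoxyphenyl gives an at least 2.1-fold lower number from compound 2 to compound 3 (0.32 log units; beyond the scatter). This second step is bounded on one side only, since compound 2 gives a limit of the assay and not a number: the limit of > 128000 nM in this assay, at which 1 of the 3 values shown sits.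

From the compounds shown here alone, it remains open what a single chlorine on this ring, as in 4-chlorophenyl, would give in this assay. Going by these compounds, the outcome with an amine or a carboxylic acid in the place of the hydroxyl is also open.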